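Sec-Butyl Side Chain on a Series of Inactive Amides

The source may report more compounds than this note shows. Statements on the series, on what has been measured and on what is new or still open speak of the compounds shown alone.

Compound 3, `C[C@H](NC(=O)[C@]1(O)C[C@@H](O)[C@@H](O)[C@H](O)C1)C(=O)O`, belongs to a small group of amino-acid amides built on the shared core of compound 1, `O=C(O)CNC(=O)[C@]1(O)C[C@@H](O)[C@@H](O)[C@H](O)C1`. In an assay on HL-60 cells for inhibition of E-selectin (Homo sapiens) (a higher number here means a weaker inhibitor, a lower number a stronger inhibitor), compound 1 gives only a limit of the assay, > 50000000 nM. Compound 2, `O=C(O)CC[C@H](NC(=O)[C@]1(O)C[C@@H](O)[C@@H](O)[C@H](O)C1)C(=O)O`, likewise reaches only a limit in this assay, > 50000000 nM. Compound 3 itself stands at a limit as well in this assay, > 50000000 nM. The three measured steps, a step that the two limits leave unreadable from compound 1 to compound 2, a step that the two limits leave unreadable from compound 1 to compound 3 and a step that the two limits leave unreadable from compound 2 to compound 3, are therefore unreadable in size, and all that can be said is the limit of > 50000000 nM in this assay, at which 3 of the 3 values shown sit.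

Compound 4, `CCC(C)[C@H](NC(=O)[C@]1(O)C[C@@H](O)[C@@H](O)[C@H](O)C1)C(=O)O`, carries sec-butyl in place of methyl on a saturated chain carbon bound to an amide-type nitrogen and a carbonyl carbon. Among the compounds with values here, the steps that bear on it are those that vary the same chain carbon, from compound 1 to compound 2 and from compound 1 to compound 3, and both left every value at the same limit, so no direction can be read from them. With nothing in the series moving off the limit, compound 4 is expected to give about 60000000 nM in this assay, between 5000000 nM and 500000000 nM. The step from compound 3 to compound 4 is thus estimated as a step that the limit leaves unreadable from compound 3 to compound 4, with a strong likelihood that the assay again reports only a limit.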

Compound 4, half-maximal inhibitory concentration: > 50000000 nM
Compound 4 was reported as a limit; the forecaster's own chance of this, stated with the estimate: 85%; the middle value lies beyond the limit too.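

In this assay compound 4 gives > 50000000 nM as a limit of the assay. Its steps from compound 1, compound 2 and compound 3 therefore cannot be read in size, and the series stays flat at the limit: the limit of > 50000000 nM in this assay, at which 4 of the 4 values shown sit. The compounds shown leave open whether any side chain on the shared core gives a measurable value in this assay at all.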